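Swapping the nitrile for a cyclopropyl amide on the sulfonate ring

This account rests on a few compounds, and the source may have more. Where it says the series, first, only, none or still open, it means among the compounds named here.

Compound 3 `N#Cc1cccc(S(=O)(=O)Oc2ccc(-c3cncn3C3CCN(C(=O)c4ccc(Cl)c(C(F)(F)F)c4)CC3)cc2)c1` stands at the strong end of the three compounds measured in an assay on HEK293 cells for antagonist activity at P2X purinoceptor 7 (Homo sapiens), read by fluorescence, with a stated time of 2 h; a lower number here means a stronger inhibitor, a higher number a weaker inhibitor: compound 3 gives 73 nM, while compound 1 `O=C(c1ccc(Cl)c(C(F)(F)F)c1)N1CCC(n2cncc2-c2ccc(OS(=O)(=O)c3ccccc3)cc2)CC1` gives 702 nM and compound 2 `O=C(c1ccc(Cl)c(C(F)(F)F)c1)N1CCC(n2cncc2-c2ccc(OS(=O)(=O)c3cccc4ccccc34)cc2)CC1` gives 3520 nM. Compound 4 `O=C(NC1CC1)c1cccc(S(=O)(=O)Oc2ccc(-c3cncn3C3CCN(C(=O)c4ccc(Cl)c(C(F)(F)F)c4)CC3)cc2)c1` has not yet been measured; it differs from compound 3 by cyclopropylcarbamoyl in place of cyano on an aromatic carbon.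

Going by the values given here, two measured steps bear on this change. Adding the cyano group produced a 9.6-fold lower number from compound 1 to compound 3 (0.98 log units; beyond the scatter), so the substituent at this position matters. Enlarging the sulfonyl aryl group produced a 5.0-fold higher number from compound 1 to compound 2 (0.70 log units; beyond the scatter), and the replacement of the naphthyl by the cyanophenyl produced a 48-fold lower number from compound 2 to compound 3 (1.68 log units; beyond the scatter). Among the compounds with values here, the cyclopropylcarbamoyl group is considerably larger than the cyano group it replaces and brings a hydrogen-bond donor, which no measured compound carries. On these numbers, the step of a 3.0-fold higher number from compound 3 to compound 4 (0.48 log units; beyond the scatter) is expected to be modest and toward a higher number, though it remains uncertain. Compound 4 is therefore estimated at 220 nM in this assay, within a range of 50 nM to 900 nM.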

Compound 4, half-maximal inhibitory concentration: 88 nM
The estimate for compound 4 lay 2.5-fold (0.40 log units) above the measured number; measured number inside the range.
By their numbers in this assay, from the lowest: compounds 3 and 4 (each within the scatter of the next); then compound 1; then compound 2.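

In this assay, replacing the nitrile with the larger cyclopropylcarbamoyl group, which brings a hydrogen-bond donor, leaves the reading unresolved from that of compound 3: the step is a 1.2-fold higher number from compound 3 to compound 4 (0.08 log units; within the scatter). The advantage over hydrogen at this position is therefore not confined to the nitrile (an 8.0-fold lower number from compound 1 to compound 4 (0.90 log units; beyond the scatter)), and the amide also reads well clear of the naphthalen-1-yl sulfonate (a 40-fold lower number from compound 2 to compound 4 (1.60 log units; beyond the scatter)). Nothing measured here explains why the two groups read alike.

The compounds leave open whether the amide hydrogen contributes at all, a question that a dimethylcarbamoyl group, which lacks that hydrogen, would address, as would a carboxylic acid or a primary amine at the same place. They also leave open whether either group would read the same elsewhere on the ring, since both nitrile and amide stand at this one position.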